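The compounds below may be only part of what the source reports. "The series", "measured", "known", "first", "only" and "open" are said of these compounds alone.

Measured so far:
- compound 1 `COc1cc(C)c(S(=O)(=O)N(C)CCOCC(=O)N2CCC(C(C)(C)CN(C)C)CC2)c(C)c1` — 7.5
- compound 2 `COc1cc(C)c(S(=O)(=O)N(C)CCOCC(=O)N2CCN(C3CCN(C4CC4)CC3)CC2)c(C)c1` — 8.5

Both compounds were tested in a functional assay on Umbilical vein for antagonist activity at B1 bradykinin receptor (Homo sapiens), using Schild analysis, with a stated time of 30 min; a higher number here means a more potent compound, by a factor of ten per unit of this negative logarithm, a lower number a less potent compound. In this assay compound 1 gives 7.5, and compound 2 gives 8.5. Compound 2 therefore stands higher of the two, and the gap to compound 1 lies beyond the usual scatter of repeated measurements.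

The next compound, compound 3 `COc1cc(C)c(S(=O)(=O)N(C)CCOCC(=O)N2CCN([C@H]3CN4CCC3CC4)CC2)c(C)c1`, has not yet been measured. It differs from compound 2 in one place: a group of 8 heavy atoms (7 carbon, 1 nitrogen; 2 six-membered non-aromatic rings with 1 hetero atom each) in place of a group of 9 heavy atoms (8 carbon, 1 nitrogen; one three-membered non-aromatic ring of carbon only, one six-membered non-aromatic ring with 1 hetero atom), on an amine nitrogen in a ring. The group that leaves and the group that enters are of similar size, and each carries one hydrogen-bond acceptor and no hydrogen-bond donor, so both are basic amine-bearing rings attached to the same ring nitrogen. For the measured compounds named here, no pair of measured compounds shows the effect of such a swap, so the expectation rests on compound 2 alone. For compound 3 a step of a number 0.20 log units lower from compound 2 to compound 3 (within the scatter) is expected, a change not beyond the scatter. Compound 3 is thus estimated at 8.3, within a range from 7.6 to 9.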

Compound 3, negative logarithm of the antagonist equilibrium constant: 7.2
Compound 3: middle estimate off by 1.10 log units, on the high side, and the stated range ends above it.
By their numbers in this assay, from the lowest: compounds 3 and 1 (each within the scatter of the next); then compound 2.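

In this assay, the group on this amine nitrogen in a ring matters far more than its size alone would suggest: replacing 1-cyclopropylpiperidin-4-yl with the group of two six-membered rings and one defined stereocentre brings a large change (a number 1.30 log units lower from compound 2 to compound 3 (beyond the scatter)). The two groups have the same counts of hydrogen-bond donors and acceptors and differ by only one heavy atom, so similarity in these counts does not preserve potency at this position. Nothing measured here gives a reason for the change.

This single swap alters the ring system, removes the cyclopropyl and adds a stereocentre, so the compounds shown cannot separate these features. On these data alone, it remains open whether 1-methylpiperidin-4-yl at the same nitrogen would match compound 2, and how the opposite stereocentre in the group of compound 3 would compare.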